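This account rests on a few compounds, and the source may have more. Where it says the series, first, only, none or still open, it means among the compounds named here.

Measured compounds:
compound 1, `COc1cccc(CNCCCNc2ccnc3cc(Oc4ccc(Cl)cc4)ccc23)c1O`, with 14500 nM in a physicochemical assay for solubility, with a stated time of 18 h, at pH 7.4; a lower number here means a less soluble compound, a higher number a more soluble compound.
compound 2, `COc1cccc(Oc2ccc3c(NCCCNCc4cc(F)ccc4OC)ccnc3c2)c1`, with 14500 nM in this assay.

Compound 1 and compound 2 sit level in this assay at the digits given; the two values lie within the scatter of each other, so no order can be read between them. Going by the values given here, compound 1 is therefore not set apart from compound 2 on the numbers in hand, and no step between measured compounds is available to calibrate any change.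

The step of interest leads from compound 1 to compound 3, `COc1cccc(CNCCCNc2ccnc3cc(Oc4ccc(F)cc4)ccc23)c1O`, which has not been measured. The change is fluoro in place of chloro on an aromatic carbon, that is, a 4-chlorophenoxy group becomes a 4-fluorophenoxy group on the shared core. Among the compounds with values here, with no measured step to rest on, the expectation is a small rise in this assay, a 1.4-fold higher number from compound 1 to compound 3 (0.14 log units; within the scatter), a step that may not clear the scatter. Compound 3 is estimated to reach 20000 nM, with a plausible range from 8000 nM to 50000 nM.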

Compound 3, solubility: 14500 nM
Compound 3: the middle estimate sits 1.4-fold (0.14 log units) above what was measured, and the stated range covers the measured number.
By their numbers in this assay, from the lowest: compounds 1, 2 and 3 (each within the scatter of the next).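

In this assay, going by these compounds alone, fluoro in place of chloro at this position gives no change at the digits printed from compound 1 to compound 3 (within the scatter), and this is the first step in the set that isolates one change. Within the data shown here, until now no measured pair could calibrate any change, whereas here a single halogen on an aromatic carbon is exchanged and the rest of the structure is held fixed. Within the scatter, this exchange of 4-chlorophenoxy for 4-fluorophenoxy leaves the read-out undistinguished, and nothing measured alongside it offers an explanation for that.

The compounds shown leave open whether a group other than a halogen at this position, such as a nitrile, an amine or a carboxylic acid, would move the read-out in this assay beyond the scatter. They also leave open whether changes elsewhere on the shared core, such as a longer chain in the linker, would separate compounds in a way that this halogen exchange does not.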